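A few compounds are considered here, and "the series" means these few. Any claim that something is new, unique, unknown or untested is made for them only; others in the source may bear on it.

- Compound 1 `C=C(C)[C@@H]1CC=C(CN(OC)C2O[C@H](CO)[C@@H](N=[N+]=[N-])[C@H](O)[C@H]2O)CC1`: 4000 nM
- Compound 2 `C=C(C)[C@@H]1CC=C(CN(OC)C2O[C@@H](CO)[C@H](N=[N+]=[N-])[C@@H](O)[C@@H]2O)CC1`: 451000 nM
- Compound 3 `C=C(C)[C@@H]1CC=C(CN(OC)C2O[C@H](CNC(=O)CCCCCCCCC)[C@@H](O)[C@H](O)[C@H]2O)CC1`: 14000 nM

In a functional assay on A549 cells (Homo sapiens) for cytotoxicity, read by resazurin assay, with a stated time of 48 h (on this read-out lower numbers stand for stronger inhibition and higher numbers for weaker inhibition), compound 1 gives 4000 nM, the lowest of the three numbers and so the strongest inhibition in this small set. Compound 3 follows at 14000 nM, and compound 2 lies far behind at 451000 nM.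

The next compound, compound 4 `C=C(C)[C@@H]1CC=C(CN(OC)C2OC[C@@H](N=[N+]=[N-])[C@H](O)[C@H]2O)CC1`, has not yet been measured. It is compound 1 with one change: hydrogen in place of hydroxymethyl on a saturated ring carbon. In short, hydrogen takes the place of hydroxymethyl on a saturated ring carbon, while the azido group stays.

Among the compounds with values here, only one measured step links two close relatives, a 110-fold higher number from compound 1 to compound 2 (2.05 log units; beyond the scatter). Atoms and bonds stay the same in that step, and the evidence on it is the fact that one of compounds 1 and 2 is drawn with a defined configuration and the other without, at the place where they differ. Within the data shown here, it shows how far the number can move, but no measured step removes hydroxymethyl, so it gives only a loose guide to size.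

Since compound 4 keeps everything else in compound 1, which gives 4000 nM, a moderate loss is the likeliest outcome in this assay, much smaller than the step to compound 2. The expected change is a 3.0-fold higher number from compound 1 to compound 4 (0.48 log units; beyond the scatter). The estimated value for compound 4 is 12000 nM, with an expected range of 3000 nM to 60000 nM.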

Compound 4, half-maximal inhibitory concentration: 76000 nM
For compound 4 the middle estimate is 6.3-fold (0.80 log units) below the measured one; the whole stated range lies below it.
By their numbers in this assay, from the lowest: compound 1; then compound 3; then compound 4; then compound 2.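

In this assay, putting hydrogen in place of hydroxymethyl on the saturated ring carbon next to the ring oxygen gives a 19-fold higher number from compound 1 to compound 4 (1.28 log units; beyond the scatter), so this position matters to the read-out even though the azido group and the rest of compound 1 stay. Within the data shown here, until now, the only step between close relatives kept the same atoms and bonds and changed only the drawn configuration; this step is the first to show that removing a group at this place can also weaken inhibition substantially. The compounds shown give no reason for this loss, and the one available note on how compounds are drawn does not bear on it.

On these data alone, what remains open is whether the oxygen of the hydroxymethyl is needed or the carbon alone would be enough, which a methyl, an aminomethyl or a carboxylic acid at the same ring carbon could help to separate. As far as these compounds go, it is also open whether a longer chain there, with the azido group kept, would regain the inhibition, and whether removing hydroxymethyl would matter as much in the configuration of compound 2.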